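A Nitro Group Joins the Phenyl Ring of Compound 1

The source may hold more compounds than are shown below. What is called first, only, known or untested is meant among the compounds shown, and "the series" means these compounds.

Among the measured compounds shown here, compound 1 `CCOC(=O)C1=C(Nc2ccccc2)S/C(=C\c2ccc[nH]2)C1=O` gives 9500 nM in a functional assay on JAR cells (Homo sapiens) for inhibition, read by MTT assay, with a stated time of 72 h (on this read-out lower numbers stand for stronger inhibition and higher numbers for weaker inhibition), the lowest of the two numbers measured; its only measured neighbour is compound 2 `CCOC(=O)C1=C(Nc2cccc(C(F)(F)F)c2)S/C(=C\c2ccc[nH]2)C1=O`, at 19700 nM. For the measured compounds named here, the one step available, a 2.1-fold higher number from compound 1 to compound 2 (0.32 log units; beyond the scatter), shows a modest weakening when a group is added to the phenyl ring. Compound 3 `CCOC(=O)C1=C(Nc2ccc([N+](=O)[O-])cc2)S/C(=C\c2ccc[nH]2)C1=O` carries a different change: nitro in place of hydrogen on an aromatic carbon. Going by the values given here, that step is the only guide, and both the group and its place differ, so only a small shift in this assay, towards a higher number or none beyond the scatter, is expected. The estimate for compound 3 is 12000 nM, expected between 4000 nM and 40000 nM, meaning an expected step of a 1.3-fold higher number from compound 1 to compound 3 (0.10 log units; within the scatter).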

Compound 3, half-maximal inhibitory concentration: 15600 nM
Compound 3: middle estimate off by 1.3-fold (0.11 log units), on the low side; the measured number falls inside the stated range.
By their numbers in this assay, from the lowest: compounds 1, 3 and 2 (each within the scatter of the next, the first and the last beyond it).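

Putting nitro on the phenyl ring, para to a large group, gives a 1.6-fold higher number from compound 1 to compound 3 (0.22 log units; within the scatter) in this assay. Adding a group to this ring therefore need not shift the number beyond the scatter, while the trifluoromethyl of compound 2 goes against any rule that every addition does so. No measurement here explains this result.

Going by these compounds, whether an amine or a carboxylic acid at the same ring carbon would give a clear shift, in either direction, remains open. So does the effect of nitro on the other ring carbons.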